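Acetylation step in the octyl rhamnoside series

The compounds below may be only part of what the source reports. "The series", "measured", "known", "first", "only" and "open" are said of these compounds alone.

Measured so far:
compound 1 `CCCCCCCCO[C@@H]1O[C@@H](C)[C@H](OC(=O)CCCCC)[C@@H](O[C@@H]2O[C@@H](C)[C@H](OC(C)=O)[C@@H](O[C@@H]3O[C@@H](C)[C@H](O)[C@@H](O)[C@H]3OC(C)=O)[C@H]2OC(C)=O)[C@H]1O`, 25 uM
compound 2 `CCCCCCCCO[C@@H]1O[C@@H](C)[C@H](OC(=O)CCCCC)[C@@H](O[C@@H]2O[C@@H](C)[C@H](OC(C)=O)[C@@H](O)[C@H]2OC(C)=O)[C@H]1O`, > 20 uM

In a functional assay on Lu1 cells (Homo sapiens) for antiproliferative activity, read by MTT assay, with a stated time of 48 h (a higher number here means that more compound is needed for the effect, a lower number that less compound is needed), compound 1 gives 25 uM. For compound 2 the assay reports only a limit, > 20 uM, which is the limit of > 20 uM in this assay, at which 1 of the 2 values shown sits. Compound 3 `CCCCCCCCO[C@@H]1O[C@@H](C)[C@H](OC(=O)CCCCC)[C@@H](O[C@@H]2O[C@@H](C)[C@H](OC(C)=O)[C@@H](OC(C)=O)[C@H]2OC(C)=O)[C@H]1O` differs from compound 2 by acetyl in place of hydrogen on an oxygen on a saturated carbon. Among the measured compounds shown here, no measured step resembles this change, so no size is known for it; compound 2 sitting at a limit, the step in this assay a step that the limit leaves unreadable from compound 2 to compound 3 is expected to be small, in either direction or none beyond the scatter. Compound 3 is estimated at 25 uM, in the range 10 uM to 60 uM.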

Compound 3, concentration for half-maximal effect: 9 uM
Compound 3: the middle estimate sits 2.8-fold (0.44 log units) above what was measured, outside the stated range (below it).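

In this assay, among the compounds shown here, hydroxy to acetoxy on an oxygen on a saturated carbon gives an at least 2.2-fold lower number from compound 2 to compound 3 (0.34 log units; beyond the scatter), the first readable step. The free hydroxy at this place is therefore not needed for a low number in this assay. The true size of the step remains unknown, as its starting point is only a limit: the limit of > 20 uM in this assay, at which 1 of the 3 values shown sits.

Still open, as far as these compounds go, is whether a methyl ether or a benzoyl ester on the same oxygen would lower the number as acetoxy does. Also open, from the compounds shown here alone, is whether the step depends on the carbonyl.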